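This account rests on a few compounds, and the source may have more. Where it says the series, first, only, none or still open, it means among the compounds named here.

Three compounds share one core, and two of them have a number in an assay on blood for inhibition of Indoleamine 2,3-dioxygenase 1 (Homo sapiens); a lower number here means a stronger inhibitor, a higher number a weaker inhibitor. Compound 1 `O=C(Nc1ccc(Cl)cc1)C1(c2ccc3c(n2)CCN3c2ccccn2)CCC1` gives 0.34 nM in this assay. Compound 2 `Cc1nccc(N2CCc3nc(C4(C(=O)Nc5ccc(F)cc5)CCC4)ccc32)n1` is recorded in this assay as "not determined" (no result reported). Compound 3 `O=C(C1CC1)N1CCc2nc(C3(C(=O)Nc4ccc(F)cc4)CCC3)ccc21` gives 29 nM in this assay, the higher of the two numbers; the nearest neighbour, compound 1, sits at a number that is far lower, well beyond the usual scatter. The two differ in more than one place, so the gap between them shows only where each stands, not what any single change does.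

Compound 4 `O=C(c1cccc(Cl)c1)N1CCc2nc(C3(C(=O)Nc4ccc(F)cc4)CCC3)ccc21` differs from compound 3 in a single place: 3-chlorophenyl in place of cyclopropyl on a carbonyl carbon. For the measured compounds named here, no measured pair shows this exact exchange, so the direction of the step is open. A modest move is expected rather than a large one, with a downward lean, because compound 1, the only partner with an aromatic ring on the amide-type nitrogen in a ring, gives 0.34 nM. The step from compound 3 to compound 4 is estimated at a 1.9-fold lower number from compound 3 to compound 4 (0.29 log units; within the scatter). Compound 4 is therefore expected to give about 15 nM in this assay, in a range from 3 nM to 80 nM.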

Compound 4, half-maximal inhibitory concentration: 0.84 nM
Compound 4: the middle estimate sits 18-fold (1.25 log units) above what was measured, and the stated range ends above it.
By their numbers in this assay, from the lowest: compound 1; then compound 4; then compound 3.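

In this assay, the group on the carbonyl carbon turns out to matter a great deal: 3-chlorophenyl in place of cyclopropyl gives a 35-fold lower number from compound 3 to compound 4 (1.54 log units; beyond the scatter), well beyond the scatter. This is the only single change that can be read among these compounds, and it shows that this position, on a carbonyl carbon attached to an amide-type nitrogen in a ring, can strongly shift the number. Nothing in the data shown explains why the step is so large.

From the compounds shown here alone, it remains open whether the chlorine contributes to the step or a plain phenyl ring would give the same number. Also open, going by these compounds, is how a pyridine ring, a methoxyphenyl group or a simple methyl group would fare on the same carbonyl carbon.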